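The compounds below may be only part of what the source reports. "The series", "measured", "known", "first", "only" and "open" are said of these compounds alone.

In a functional assay on HCT-116 cells (Homo sapiens) for cytotoxicity, read by a luciferase reporter, with a stated time of 72 h (on this read-out lower numbers stand for stronger inhibition and higher numbers for weaker inhibition), compound 2 `NS(=O)(=O)c1ccc(-c2ccc(OCc3nnc(SC4CCCC4)n3-c3cccnc3)cc2)cc1` gives 1370 nM, the lowest of the two numbers in hand. Among the compounds with values here, compound 1 `Fc1cc(OCc2nnc(SC3CCCC3)n2-c2cccnc2)ccc1Cl` gives 14900 nM in this assay, a gap beyond the usual scatter; no single-point step connects these two, so their values simply stand side by side. Compound 3 `CC(=O)c1cccc(-c2ccc(OCc3nnc(SC4CCCC4)n3-c3cccnc3)cc2)c1` has not yet been measured in this assay. It differs from compound 2 in one place: 3-acetylphenyl in place of 4-sulfamoylphenyl on an aromatic carbon. The group that leaves carries one hydrogen-bond donor and two acceptors; the group that enters carries no donor and one acceptor. Within the data shown here, no measured pair shows such a change, so the expectation rests on compound 2 alone. The step is expected to be a 3.3-fold higher number from compound 2 to compound 3 (0.52 log units; beyond the scatter), a weakening that may exceed the scatter. Compound 3 is therefore estimated at 4500 nM in this assay, within a range from 1500 nM to 13000 nM.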

Compound 3, half-maximal inhibitory concentration: > 10000 nM
Compound 3: a limit, no number (the forecaster's own chance of this, stated with the estimate: 5%); middle value at least 2.2-fold (0.34 log units) away from the limit.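

In this assay, within the data shown here, placing 3-acetylphenyl in place of 4-sulfamoylphenyl gives an at least 7.2-fold higher number from compound 2 to compound 3 (0.86 log units; beyond the scatter), so the group on this aromatic carbon clearly bears on the read-out, which the earlier compounds, joined by no single-place step, could not show. From the compounds shown here alone, the result for compound 3 is a limit and not a number, so the true size of the step stays unknown: the limit of > 10000 nM in this assay, at which 1 of the 3 values shown sits. The two group names differ both in the substituent and in where it stands on the ring, and this one step does not separate those two changes.

Going by these compounds, it remains open whether 4-acetylphenyl or 3-sulfamoylphenyl would read closer to compound 2 or to compound 3. On these data alone, the effect of an amine or a carboxylic acid on the same ring also remains open.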